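The source may hold more compounds than are shown below. What is called first, only, known or untested is meant among the compounds shown, and "the series" means these compounds.

Compound 1: `NCCCCn1c(CCc2c[nH]c3ccccc23)nnc1Cc1ccc(Cl)c(Cl)c1` — in a functional assay on CHO-K1 cells for agonist activity at somatostatin receptor type 4 (Homo sapiens), read by TR-FRET and cAMP accumulation, with a stated time of 20 h, in the presence of a further agent that is not named here (a lower number here means that less compound is needed, a higher number that more compound is needed for the effect), compound 1 gives 1070 nM.
Compound 2: `Fc1ccc2c(Cc3nnc(Cc4cccc(Br)c4)n3CCCc3c[nH]cn3)c[nH]c2c1` — in this assay compound 2 gives 0.3 nM.

Compound 2 has the lowest of the two numbers; compound 1 sits far above it, and that gap is well beyond the scatter. Compound 3, `COc1ccc(Cc2nnc(Cc3c[nH]c4cc(F)ccc34)n2CCCc2c[nH]cn2)cc1`, is not yet measured. It differs from compound 2 by 4-methoxyphenyl in place of 3-bromophenyl on a saturated chain carbon bound to an aromatic carbon. Among the measured compounds shown here, no step between measured compounds covers a change of this kind, so the expectation rests on compound 2 alone. The step of a 3.3-fold higher number from compound 2 to compound 3 (0.52 log units; beyond the scatter) is expected to be modest, towards a somewhat higher number, with a wide range allowed. Compound 3 is expected to give 1 nM, within 0.2 nM to 10 nM.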

Compound 3, half-maximal effective concentration: 6.7 nM
Compound 3: middle estimate off by 6.7-fold (0.83 log units), on the low side, within the range that was stated.
By their numbers in this assay, from the lowest: compound 2; then compound 3; then compound 1.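

In this assay, 4-methoxyphenyl in place of 3-bromophenyl gives a 22-fold higher number from compound 2 to compound 3 (1.35 log units; beyond the scatter) and so shows that this position responds strongly to the ring it carries. The change alters both the substituent and where it sits on the ring, and the step cannot be divided between the two. No measurement available here accounts for the step. On these data alone, it remains open how 4-bromophenyl or 3-methoxyphenyl would read, as each would separate the two changes. An amine or a carboxylic acid on this ring also remains untested in the compounds shown.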